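The source may report more compounds than this note shows. Statements on the series, on what has been measured and on what is new or still open speak of the compounds shown alone.

Measured so far:
Compound 1 `COCc1cc(OC)c(-c2csc3c(N(CC4CC4)CC4CCOC4)c(OC)nn23)c(OC)c1`: 48 nM
Compound 2 `CCN(c1c(OC)nn2c(-c3c(OC)cc(COC)cc3OC)csc12)C1CCOCC1`: 147 nM

Within the data shown here, in an assay on HEK293 cells for displacement of a labelled ligand from corticotropin-releasing factor receptor 1 (Homo sapiens), read by scintillation proximity assay, with a stated time of 2 h (on this read-out lower numbers stand for stronger inhibition and higher numbers for weaker inhibition), compound 2 gives the higher of the two numbers; the only measured step, a 3.1-fold higher number from compound 1 to compound 2 (0.49 log units; beyond the scatter), replaces the whole amine group. Compound 3 `CCCN(c1c(OC)nn2c(-c3c(OC)cc(COC)cc3OC)csc12)C1CCOCC1` differs from compound 2 by methyl in place of hydrogen on a saturated chain carbon, two bonds along the chain from a nitrogen on an aromatic ring. Among the measured compounds shown here, no measured step bears on such a methyl-for-hydrogen change, and the one step known alters far more of the molecule, so for compound 3 the expected step is within the scatter, a 1.1-fold lower number from compound 2 to compound 3 (0.05 log units; within the scatter), with no settled direction. Compound 3 is estimated at 130 nM, with a range from 50 nM to 350 nM.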

Compound 3, half-maximal inhibitory concentration: 98 nM
For compound 3 the middle estimate is 1.3-fold (0.12 log units) above the measured one, and the stated range covers the measured number.
By their numbers in this assay, from the lowest: compound 1; then compounds 3 and 2 (each within the scatter of the next).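

In this assay, ethyl to propyl gives a 1.5-fold lower number from compound 2 to compound 3 (0.18 log units; within the scatter), so a methyl added on this saturated chain carbon, two bonds along the chain from a nitrogen on an aromatic ring, makes no difference that can be told from the scatter. The whole amine group still matters modestly, with a 2.0-fold higher number from compound 1 to compound 3 (0.31 log units; beyond the scatter) as the smaller of the two steps that replace it. No measurement here explains either step.

As far as these compounds go, whether a longer chain such as butyl would stay in this range remains open. So does the effect of an amine or a hydroxyl group at the end of that chain.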